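The source may report more compounds than this note shows. Statements on the series, on what has been measured and on what is new or still open speak of the compounds shown alone.

In a functional assay on MCF7 cells (Homo sapiens) for antiproliferative activity, read by sulforhodamine B assay, with a stated time of 72 h (a lower number here means a stronger inhibitor, a higher number a weaker inhibitor), three compounds sharing one core have been measured. Compound 1 `CCN1C(=O)CS/C1=N/Nc1nncc2ccccc12` gives 98 nM and compound 3 `S=C(NNc1nncc2ccccc12)Nc1ccccc1` gives 47 nM while compound 2 `Cc1cc(C)nc(NS(=O)(=O)c2ccc(Nc3nncc4ccccc34)cc2)n1` gives 7.7 nM as the lowest of the three numbers, clear of both others by more than the usual scatter. Compound 4 `O=S(=O)(Nc1nccs1)c1ccc(Nc2nncc3ccccc23)cc1` has no number yet. It differs from compound 2 by 1,3-thiazol-2-yl in place of 4,6-dimethylpyrimidin-2-yl on a sulfonamide nitrogen. Going by the values given here, no measured pair shows a swap of this kind, so the expectation is loose: a small rise in this assay that would mean a somewhat weaker inhibitor, at about the edge of the scatter. The expected step is one (a 2.1-fold higher number from compound 2 to compound 4 (0.32 log units; beyond the scatter)). The estimated value for compound 4 is 16 nM with an expected range from 4 nM to 60 nM ( an estimate only ).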

Compound 4, half-maximal inhibitory concentration: 55 nM
Compound 4: the middle estimate sits 3.4-fold (0.54 log units) below what was measured; measured number inside the range.
By their numbers in this assay, from the lowest: compound 2; then compounds 3, 4 and 1 (each within the scatter of the next, the first and the last beyond it).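

In this assay, going by these compounds alone, the step of a 7.1-fold higher number from compound 2 to compound 4 (0.85 log units; beyond the scatter) is the first measured pair with a single change, and it shows that the ring on the sulfonamide nitrogen matters: these two aromatic rings are not interchangeable here. Nothing available gives a reason for this step.

The change swaps a six-membered ring carrying two methyl groups for a five-membered ring with a sulfur atom, so the compounds shown cannot say which of these differences accounts for the step. An unsubstituted pyrimidin-2-yl group or a plain phenyl ring at this place would help separate them.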